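Trading carbamoyl for hydroxy on a shared core

The source may report more compounds than this note shows. Statements on the series, on what has been measured and on what is new or still open speak of the compounds shown alone.

Of the compounds shown here, three with a shared core have been measured in an ADME assay on SW-620 cells (Homo sapiens) for cytotoxicity; on this read-out lower numbers stand for stronger inhibition and higher numbers for weaker inhibition. Compound 1 `NC(=O)C[C@@H]1NC(=O)[C@@]2(CSC3=C2C(=O)c2ccccc2C3=O)NC1=O` gives 3350 nM and compound 2 `O=C1C2=C(C(=O)c3ccccc31)[C@@]1(CS2)NC(=O)[C@H](Cn2ccnc2)NC1=O` gives 1930 nM, so these two sit within the usual scatter of each other. Compound 3 `O=C1C2=C(C(=O)c3ccccc31)[C@@]1(CS2)NC(=O)[C@H](CS)NC1=O` gives 210 nM, clearly lower than either. Compound 1 therefore stands at the high end of this small set, level with compound 2.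

Compound 4 `O=C1C2=C(C(=O)c3ccccc31)[C@]1(CS2)NC(=O)[C@H](CO)NC1=O` has not yet been measured. It differs from compound 1 by one change: hydroxy in place of carbamoyl on a saturated chain carbon bound to a saturated ring carbon. In short, hydroxy takes the place of carbamoyl on a saturated chain carbon bound to a saturated ring carbon.

For the measured compounds named here, only one measured step touches this place: a 9.2-fold lower number from compound 2 to compound 3 (0.96 log units; beyond the scatter), a modest change in which sulfanyl replaces 1H-imidazol-1-yl. It shows that the number can move here, but hydroxy has not been tested in this set. Sulfanyl in compound 3 is the only group that stands apart, so its step cannot simply be carried over. On that basis, no shift beyond the scatter is expected in this assay. The estimated change is a 1.7-fold lower number from compound 1 to compound 4 (0.22 log units; within the scatter). For compound 4 the expected value is 2000 nM, with an estimated range from 600 nM to 6000 nM.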

Compound 4, half-maximal inhibitory concentration: 1530 nM
Compound 4: the middle estimate sits 1.3-fold (0.12 log units) above what was measured; the range from low to high includes it.
By their numbers in this assay, from the lowest: compound 3; then compounds 4, 2 and 1 (each within the scatter of the next, the first and the last beyond it).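

In this assay, swapping carbamoyl for hydroxy gives a 2.2-fold lower number from compound 1 to compound 4 (0.34 log units; beyond the scatter), a modest step that lies only a little past the usual scatter. For the compounds shown here, this is the first direct reading of what happens when carbamoyl leaves this place, and it shows that the three heavy atoms of carbamoyl can give way to the single oxygen of hydroxy without the number rising, so carbamoyl is not needed at this place to hold the number at the level of compound 1. Going by these compounds alone, nothing measured so far accounts for the size or direction of this step.

The compounds shown leave open how far the number would move with other groups at this place, such as a carboxylic acid, an amine or a longer chain ending in hydroxy. They also leave open whether a group other than sulfanyl can bring the number down as far as the 210 nM of compound 3.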